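Swapping the aryl amine substituent on a shared core

The compounds below may be only part of what the source reports. "The series", "measured", "known", "first", "only" and "open" are said of these compounds alone.

Of the compounds shown here, three of a shared core have been measured in a functional assay on HT29-AK cells (Homo sapiens) for cytotoxicity, read by MTT assay, with a stated time of 48 h; a lower number here means a stronger inhibitor, a higher number a weaker inhibitor. Compound 1 `COc1ccc(Nc2nc(-c3cccc(F)c3)nc3ccc(F)cc23)cc1` gives 42300 nM in this assay. Compound 2 `Fc1cccc(-c2nc(Nc3ccccc3Cl)c3cc(F)ccc3n2)c1` reaches only the limit of this assay, > 50000 nM, which is a limit and not a number. Compound 3 `Oc1ccc(Nc2nc(-c3cccc(F)c3)nc3ccc(F)cc23)cc1` likewise stands at a limit in this assay, > 50000 nM, so only a floor is known for it. In this assay two of the three values sit at the same limit (the limit of > 50000 nM in this assay, at which 2 of the 3 values shown sit), so compound 3 stands among the weakest values shown, with no number to rank it.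

Compound 4 `Nc1cccc(Nc2nc(-c3cccc(F)c3)nc3ccc(F)cc23)c1` differs from compound 3 at the nitrogen on the aromatic ring: 3-aminophenyl in place of 4-hydroxyphenyl on a nitrogen on an aromatic ring. The measured steps that touch this place are an at least 1.1-fold higher number from compound 1 to compound 3 (0.07 log units; that floor lies within the scatter) and a step that the two limits leave unreadable from compound 2 to compound 3; neither mirrors the change to a 3-aminophenyl group, and both end at the limit. Nothing shown separates compound 3 from compound 2 beyond that limit. The expectation for compound 4 is therefore a step of an at least 1.1-fold lower number from compound 3 to compound 4 (0.04 log units; that floor lies within the scatter) in this assay, that is, no change resolvable beyond the scatter. Compound 4 is thus expected to give about 45000 nM in this assay, estimated between 15000 nM and 150000 nM, and most likely reported as a limit again.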

Compound 4, half-maximal inhibitory concentration: > 50000 nM
Compound 4 gave a limit, no number (the forecaster's own chance of this, stated with the estimate: 65%); middle value at least 1.1-fold (0.04 log units) from the limit.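

Going by these compounds, with compound 4, a 3-aminophenyl group joins 2-chlorophenyl and 4-hydroxyphenyl as a third group on this nitrogen that gives a limit and not a number in this assay; moving the substituted group from a 4-hydroxyphenyl to a 3-aminophenyl pattern therefore yields no measurable value at this place: the limit of > 50000 nM in this assay, at which 3 of the 4 values shown sit. The steps linking compound 4 to compound 2 and to compound 3 cannot be read, as each joins two limits, so the order of these three compounds remains unknown. The one readable step is an at least 1.1-fold higher number from compound 1 to compound 4 (0.07 log units; that floor lies within the scatter), so even the 4-methoxyphenyl group of compound 1, the only one here with a number, is not shown to differ from the 3-aminophenyl group beyond the scatter.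

The compounds shown leave open whether any group on this nitrogen can bring the value clearly under the limit, for instance a benzyl group or a longer chain ending in an amine. They also leave open whether a change elsewhere on the shared core, such as a carboxylic acid in place of one of its fluorine atoms, would alter the reading.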